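The source may hold more compounds than are shown below. What is called first, only, known or untested is meant among the compounds shown, and "the series" means these compounds.

Measured in a functional assay on MCF7 cells (Homo sapiens) for antiproliferative activity, read by MTT assay, with a stated time of 72 h; on this read-out higher numbers stand for weaker inhibition and lower numbers for stronger inhibition:
- compound 1 `CCCCc1cn(C[C@H](O)[C@H]2OC(=O)C(OCc3ccccc3)=C2OCc2ccccc2)nn1`: 7910 nM
- compound 2 `COc1ccccc1-c1cn(C[C@H](O)[C@H]2OC(=O)C(OCc3ccccc3)=C2OCc2ccccc2)nn1`: > 100000 nM, a limit
- compound 3 `CCCCCCCCCCc1cn(C[C@H](O)[C@H]2OC(=O)C(OCc3ccccc3)=C2OCc2ccccc2)nn1`: 80 nM

Compound 3 stands lowest of the three, and the nearest number lies far off: a 99-fold lower number from compound 1 to compound 3 (2.00 log units; beyond the scatter). Compound 4 `Cc1ccc(-c2cn(C[C@H](O)[C@H]3OC(=O)C(OCc4ccccc4)=C3OCc3ccccc3)nn2)cc1` carries 4-methylphenyl in place of decyl on an aromatic carbon. The closest measured step runs the opposite way in structure, since it also exchanges an aryl group and decyl: an at least 1200-fold lower number from compound 2 to compound 3 (3.09 log units; beyond the scatter). The step of an at least 12-fold higher number from compound 1 to compound 2 (1.10 log units; beyond the scatter) also points upward when an aryl group enters. A large rise in the number, beyond the scatter, is therefore expected in this assay. The expected step is a 380-fold higher number from compound 3 to compound 4 (2.57 log units; beyond the scatter). For compound 4 the estimated value is 30000 nM, with an expected range of 6000 nM to 100000 nM.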

Compound 4, half-maximal inhibitory concentration: > 100000 nM
Compound 4: a limit, no number; the forecaster's own chance of this, stated with the estimate: 35%; at least 3.3-fold (0.52 log units) between middle value and limit.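

In this assay the value of compound 4 is a limit. On this aromatic carbon, 4-methylphenyl joins 2-methoxyphenyl at the top of the range, so the loss against the chains is not confined to a single aryl group: an at least 1200-fold higher number from compound 3 to compound 4 (3.09 log units; beyond the scatter) and an at least 12-fold higher number from compound 1 to compound 4 (1.10 log units; beyond the scatter). The step between compound 2 and compound 4 cannot be read because both values are limits: the limit of > 100000 nM in this assay, at which 2 of the 4 values shown sit.

Open, as far as these compounds go, is whether an aryl group carrying an amine or a carboxylic acid would give a readable number here. Also open, from the compounds shown here alone, is how a chain longer than decyl would compare with compound 3.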